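Moving a Hydroxyl Across a Phenyl Ring on a Pyridine Core

A few compounds are considered here, and "the series" means these few. Any claim that something is new, unique, unknown or untested is made for them only; others in the source may bear on it.

Four compounds sharing one core are compared here for their effect in a functional assay on HCT-15 cells (Homo sapiens) for inhibition; a lower number here means a stronger inhibitor, a higher number a weaker inhibitor. Compound 1 has the structure `Oc1cccc(-c2cc(-c3cccc(F)c3)cc(-c3cccc(O)c3)n2)c1` and in this assay compound 1 gives 7860 nM. Compound 2, `Oc1ccc(-c2cc(-c3cccc(F)c3)cc(-c3cccc(O)c3)n2)cc1`, differs from it by a single change, (4-hydroxyphenyl in place of 3-hydroxyphenyl on an aromatic carbon), and in this assay compound 2 gives 3070 nM. That change produced a 2.6-fold lower number from compound 1 to compound 2 (0.41 log units; beyond the scatter).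

Compound 3 has the structure `Oc1cccc(-c2cc(-c3ccc(OC(F)(F)F)cc3)cc(-c3cccc(O)c3)n2)c1`. For compound 3 in this assay only a limit is known, > 50000 nM; this is the bound of the assay and not a number, the one described by the limit of > 50000 nM in this assay, at which 1 of the 3 values shown sits. How the core of compound 3 differs from the core of compound 1 is not broken down here.

Compound 4, `Oc1ccc(-c2cc(-c3ccc(OC(F)(F)F)cc3)cc(-c3cccc(O)c3)n2)cc1`, has not yet been measured in this assay. It arises from compound 3 by 4-hydroxyphenyl in place of 3-hydroxyphenyl on an aromatic carbon, the same kind of change as that from compound 1 to compound 2, though the surroundings differ: in compound 1 the place is meta to a 3-fluorophenyl group and meta to a 3-hydroxyphenyl group, while in compound 3 it is meta to a 3-hydroxyphenyl group and meta to a large group.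

Since the step from compound 1 to compound 2 was modest, a similarly modest step is expected for compound 4, namely an at least 1.6-fold lower number from compound 3 to compound 4 (0.22 log units; that floor lies within the scatter), starting from a limit. Compound 4 is therefore estimated to give about 30000 nM in this assay, with a range from 10000 nM to 100000 nM and a real chance that only a limit is reported again.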

Compound 4, half-maximal inhibitory concentration: 1380 nM
Beside the measured number, compound 4's estimate is 22-fold (1.34 log units) above it; the whole stated range lies above it.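

In this assay, 4-hydroxyphenyl in place of 3-hydroxyphenyl gave an at least 36-fold lower number from compound 3 to compound 4 (1.55 log units; beyond the scatter), so the number falls on both cores shown, but the size of the fall is not the same on the two: the same change on two cores in this assay, a 2.6-fold lower number (0.41 log units; beyond the scatter) from compound 1 to compound 2 and an at least 36-fold lower number (1.55 log units; beyond the scatter) from compound 3 to compound 4, at least 14-fold (1.15 log units) apart, beyond the scatter of two such steps

Compound 3 is known only as a limit of the assay and not as a number, so this second step has a floor and no known upper end: the limit of > 50000 nM in this assay, at which 1 of the 4 values shown sits.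

The direction of the change therefore carried from one core to the other and its size did not, yet two pairs give no rule for further cores, and they do not show which feature of the cores sets the gap or how large it truly is.

The compounds shown leave open whether the same change would lower the number again if an amine or a carboxylic acid stood in place of the group that separates the two cores. They also leave open whether a methoxy group in place of the hydroxyl of the 4-hydroxyphenyl group would keep the value of compound 4, 1380 nM, in this assay.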